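A few compounds are considered here, and "the series" means these few. Any claim that something is new, unique, unknown or untested is made for them only; others in the source may bear on it.

Compound 1 `CC(C(=O)NCc1ccc(C(F)(F)F)cc1)c1ccc(NS(C)(=O)=O)c(F)c1` gives 660 nM in an assay on CHO cells for displacement of a labelled ligand from transient receptor potential cation channel subfamily V member 1 (Rattus norvegicus); a lower number here means a stronger inhibitor, a higher number a weaker inhibitor.
Compound 2 `Cc1ccc(CNC(=O)C(C)c2ccc(NS(C)(=O)=O)c(F)c2)cc1` gives 3100 nM.
Compound 3 `CC(C(=O)NCc1ccc(C2C=CCC2)cc1)c1ccc(NS(C)(=O)=O)c(F)c1` gives 162 nM.

Compound 3 stands lowest of the three numbers: a 4.1-fold lower number from compound 1 to compound 3 (0.61 log units; beyond the scatter), and a 19-fold lower number from compound 2 to compound 3 (1.28 log units; beyond the scatter). Compound 4 `CC(C(=O)NCc1ccc(C2CCCC2)cc1)c1ccc(NS(C)(=O)=O)c(F)c1` differs from compound 3 in one place: cyclopentyl in place of cyclopent-2-en-1-yl on an aromatic carbon. Going by the values given here, no measured step bears directly on this change. Both steps into compound 3, a 4.1-fold lower number from compound 1 to compound 3 (0.61 log units; beyond the scatter) and a 19-fold lower number from compound 2 to compound 3 (1.28 log units; beyond the scatter), exchange the whole group on that aromatic carbon for a much different one, whereas here the group that leaves and the group that enters each hold a five-membered non-aromatic ring of carbon only and differ by a single double bond. Compound 4 is therefore expected to sit near compound 3, with a 1.2-fold higher number from compound 3 to compound 4 (0.09 log units; within the scatter) not beyond the scatter. Compound 4 is estimated at 200 nM, within 80 nM to 500 nM.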

Compound 4, inhibition constant: 93 nM
Estimate against measurement, compound 4: 2.2-fold (0.33 log units) above; measured number inside the range.
By their numbers in this assay, from the lowest: compounds 4 and 3 (each within the scatter of the next); then compound 1; then compound 2.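

In this assay, saturating the ring leaves the number within the scatter, with a 1.7-fold lower number from compound 3 to compound 4 (0.24 log units; within the scatter), so the double bond makes no measurable difference at this aromatic carbon. The advantage of the five-membered ring over the smaller groups therefore does not rest on that double bond: compound 4 also shows a 33-fold lower number from compound 2 to compound 4 (1.52 log units; beyond the scatter) and a 7.1-fold lower number from compound 1 to compound 4 (0.85 log units; beyond the scatter).

From the compounds shown here alone, whether a cyclohexyl ring, an open butyl chain or a ring holding an amine would do as well at this position stays open. No measurement given here accounts for these steps.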